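A few compounds are considered here, and "the series" means these few. Any claim that something is new, unique, unknown or untested is made for them only; others in the source may bear on it.

Compound 1 `O=C(CCCCCCNC(=O)C(O)(O)C(F)(F)F)Nc1ncc(-c2ccc(Br)cc2)s1`: 930 nM
Compound 2 `COc1ccc(NC(=O)CCCCCCNC(=O)C(O)(O)C(F)(F)F)cc1`: "not determined" (no result reported)
Compound 3 `COc1ccc2sc(NC(=O)CCCCCCNC(=O)C(O)(O)C(F)(F)F)nc2c1`: 1230 nM

These entries come from a functional assay on cells (Panel NCI-60 (60 carcinoma cell lines), Homo sapiens) for inhibition, read by colorimetric assay, with a stated time of 3 days; on this read-out higher numbers stand for weaker inhibition of growth and lower numbers for stronger inhibition of growth. Compound 1 at 930 nM and compound 3 at 1230 nM lie within the usual scatter of each other. Compound 2 has no single number, so it gives no starting value on this scale. The next structure is compound 4 `O=C(CCCCCCNC(=O)C(O)(O)C(F)(F)F)Nc1ccc(Cl)cc1`. The change is chloro in place of methoxy on an aromatic carbon, with chloro in place of methoxy on an aromatic carbon, para to a large group. The data cannot show the size of this step, but no step beyond the scatter is expected in this assay, in either direction. For the measured compounds named here, the only guides are the two measured values. The estimate for compound 4 is 1500 nM, with an expected range of 600 nM to 5000 nM.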

Compound 4, concentration for 50% growth inhibition: 5130 nM
Beside the measured number, compound 4's estimate is 3.4-fold (0.53 log units) below it; measured number above the stated range.
By their numbers in this assay, from the lowest: compounds 1 and 3 (each within the scatter of the next); then compound 4.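

For the compounds shown here, compound 2 has no number, so no step from compound 2 to compound 4 can be read. From the compounds shown here alone, whether chloro in place of methoxy changes growth inhibition stays open. No measured evidence bears on this result.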